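Working notes on cell tolerance in a four-compound series

The compounds below may be only part of what the source reports. "The series", "measured", "known", "first", "only" and "open" are said of these compounds alone.

Compound 1 `CC(=O)OC[C@H]1O[C@@H](CC(=O)CC2(O)C(=O)N(Cc3ccccc3)c3ccccc32)[C@H](OC(C)=O)[C@@H](OC(C)=O)[C@@H]1OC(C)=O` and compound 2 `CC(=O)OC[C@H]1O[C@@H](CC(=O)CC2(O)C(=O)Nc3ccc(Cl)cc32)[C@H](OC(C)=O)[C@@H](OC(C)=O)[C@@H]1OC(C)=O` carry the same acetylated sugar arm as compound 3 `CCCCN1C(=O)/C(=C\C(=O)C[C@@H]2O[C@H](COC(C)=O)[C@@H](OC(C)=O)[C@H](OC(C)=O)[C@H]2OC(C)=O)c2ccccc21`, but neither has a number in an ADME assay on Vero cells (Chlorocebus sabaeus) for cytotoxicity, read by resazurin assay, with a stated time of 72 h; a higher number here means that more compound is tolerated, a lower number that less compound is tolerated: compound 1 gives "not determined" (no result reported) and compound 2 gives "not determined" (no result reported). Compound 3 therefore stands alone on the numbers shown; in this assay compound 3 gives 126000 nM, the only measured tolerance in the series, so it can be ranked against nothing. Compound 4 `CC(=O)OC[C@H]1O[C@@H](CC(=O)/C=C2\C(=O)N(Cc3ccc(Br)cc3)c3ccccc32)[C@H](OC(C)=O)[C@@H](OC(C)=O)[C@@H]1OC(C)=O` is the next entry for this assay. It differs from compound 3 in one place: 4-bromophenyl in place of propyl on a saturated chain carbon bound to an amide-type nitrogen in a ring. For the measured compounds named here, no measured pair carries this or any other single change, so the size of the step has no precedent here. The expectation is a small step from compound 3 to compound 4, toward somewhat less tolerance, most likely not beyond the usual scatter, a 1.6-fold lower number from compound 3 to compound 4 (0.20 log units; within the scatter). For compound 4 the estimated value in this assay is 80000 nM, with a range from 30000 nM to 200000 nM.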

Compound 4, half-maximal cytotoxic concentration: 76500 nM
Estimate against measurement, compound 4: 1.0-fold (0.02 log units) above; the measured number falls inside the stated range.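

In this assay, the exchange of propyl for 4-bromophenyl on a saturated chain carbon bound to an amide-type nitrogen in a ring gives a 1.6-fold lower number from compound 3 to compound 4 (0.22 log units; within the scatter). For the compounds shown here, this is the first single change that can be read at all, and it shows that this position accepts a group with one six-membered aromatic ring and a bromine without the two compounds separating in this read-out. Nothing shown offers a reason for this outcome.

A single pair cannot show whether the same holds for a group of another kind at this position, such as an amine, a carboxylic acid or a longer chain. Compound 1 and compound 2 give no number, so the hydroxyl-bearing form of the series remains unplaced against compound 3 and compound 4.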